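Substituent change from compound 2 to compound 3

A few compounds are considered here, and "the series" means these few. Any claim that something is new, unique, unknown or untested is made for them only; others in the source may bear on it.

Among the compounds with values here, compound 2 `CC(C)(C)c1cn(C[C@H](O)[C@H]2OC(=O)C(OCc3ccccc3)=C2OCc2ccccc2)nn1` is the only member of the pair with a number in a functional assay on HCT-116 cells (Homo sapiens) for antiproliferative activity, read by MTT assay, with a stated time of 72 h (a higher number here means a weaker inhibitor, a lower number a stronger inhibitor), where compound 2 gives 28300 nM. Compound 1 `CC(C)(C)OC(=O)N1CCN(C(=S)SCc2cn(C[C@H](O)[C@H]3OC(=O)C(OCc4ccccc4)=C3OCc3ccccc3)nn2)CC1` gives > 100000 nM in this assay, which is a limit of the assay and not a number (the limit of > 100000 nM in this assay, at which 1 of the 2 values shown sits). Compound 3 `Cc1ccc(S(=O)(=O)NCc2cn(C[C@H](O)[C@H]3OC(=O)C(OCc4ccccc4)=C3OCc3ccccc3)nn2)cc1` carries (((4-methylphenyl)sulfonyl)amino)methyl in place of tert-butyl on an aromatic carbon, (((4-methylphenyl)sulfonyl)amino)methyl in place of tert-butyl on an aromatic carbon. Within the data shown here, no measured pair shows a step of this kind. The expected step of a 1.8-fold higher number from compound 2 to compound 3 (0.25 log units; within the scatter) is a modest loss, or nothing beyond the scatter. Compound 3 is expected at 50000 nM, within 15000 nM to 160000 nM.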

Compound 3, half-maximal inhibitory concentration: 13100 nM
Beside the measured number, compound 3's estimate is 3.8-fold (0.58 log units) above it; measured number below the stated range.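

In this assay, within the data shown here, the aromatic carbon of the five-membered ring accepts (((4-methylphenyl)sulfonyl)amino)methyl in place of tert-butyl, with a 2.2-fold lower number from compound 2 to compound 3 (0.33 log units; beyond the scatter) as the first measured step at this position. A much larger group carrying an aromatic ring and a hydrogen-bond donor therefore costs nothing here and gives a modest gain. Compound 1 stays a limit of the assay, not a number: the limit of > 100000 nM in this assay, at which 1 of the 3 values shown sits.

Which part of the new group carries the gain remains open, whether the 4-methylphenyl ring or the sulfonyl unit. An aminomethyl group or a carboxylic acid on the same carbon would help separate these.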